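Swapping methoxy for chloro under an assay limit

The source may hold more compounds than are shown below. What is called first, only, known or untested is meant among the compounds shown, and "the series" means these compounds.

- compound 1 `COc1ccc(O)c2c(=O)ccn(C)c12`: > 40000 nM
- compound 2 `COc1ccc(OC)c2c(O)ccnc12`: > 40000 nM
- compound 3 `COc1cc(OC)c2c(=O)ccn(C)c2c1`: > 40000 nM

In a functional assay on L1210 cells (Mus musculus) for antiproliferative activity (on this read-out higher numbers stand for weaker inhibition and lower numbers for stronger inhibition), compound 2 gives > 40000 nM, which is a limit of the assay and not a number. Compound 2 shares its standing with the other two: the limit of > 40000 nM in this assay, at which 3 of the 3 values shown sit. Compound 4 `COc1ccc(Cl)c2nccc(O)c12` carries chloro in place of methoxy on an aromatic carbon, para to a methoxy group: chloro in place of methoxy on an aromatic carbon. Among the compounds with values here, no measured pair gives the size of such a change, and the only guide is the limit of compound 2, > 40000 nM. The expected step of a number no higher from compound 2 to compound 4 (the limit leaves the size open) is therefore none beyond the scatter, in neither direction. For compound 4 the estimated value is 40000 nM, with an expected range of 15000 nM to 80000 nM.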

Compound 4, half-maximal inhibitory concentration: > 40000 nM
Compound 4: no number, only a limit; the forecaster's own chance of this, stated with the estimate: 80%; the middle value lies on the limit itself.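

In this assay, within the data shown here, compound 4 gives > 40000 nM, a limit and not a number, as compound 2 also does, so no step between the two can be read. The compounds shown leave open how chloro and methoxy compare here.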